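Swapping a halogen on the sulfonamide ring

The source may hold more compounds than are shown below. What is called first, only, known or untested is meant among the compounds shown, and "the series" means these compounds.

Compound 2, `O=C(NCc1ccc(CNS(=O)(=O)c2ccccc2F)cc1)c1ccc(F)cc1`, gives 10 nM in an assay on MDA-MB-231 cells for binding affinity to C-X-C chemokine receptor type 4 (Homo sapiens), read by fluorescence and microscopy, with stated times of 10 min and 30 min; a higher number here means that more compound is needed for the effect, a lower number that less compound is needed; that is the lowest of the two numbers in hand. Compound 1, `O=C(NCc1ccc(CNS(=O)(=O)c2cccc(C(F)(F)F)c2)cc1)c1ccc(F)cc1`, gives 100 nM, and the step of a 10-fold lower number from compound 1 to compound 2 (1.00 log units; beyond the scatter) is the only measured one. Compound 3, `O=C(NCc1ccc(CNS(=O)(=O)c2ccccc2Cl)cc1)c1ccc(F)cc1`, differs from compound 2 by chloro in place of fluoro on an aromatic carbon. Going by the values given here, no measured step involves this halogen exchange, so the one known step gives only weak guidance. For compound 3 a change of a 1.2-fold higher number from compound 2 to compound 3 (0.08 log units; within the scatter) in this assay is expected, within the scatter. Compound 3 is estimated at 12 nM, with a range from 4 nM to 40 nM.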

Compound 3, effective concentration (reported as EC, without a stated level of effect): 1000 nM
Compound 3: middle estimate off by 83-fold (1.92 log units), on the low side; the whole stated range lies below it.
By their numbers in this assay, from the lowest: compound 2; then compound 1; then compound 3.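

The single atom ortho to a large group decides much of the result here: chloro in place of fluoro gives a 100-fold higher number from compound 2 to compound 3 (2.00 log units; beyond the scatter) even though the exchange swaps one heavy atom for one heavy atom. The change to 2-chlorophenyl also gives a 10-fold higher number from compound 1 to compound 3 (1.00 log units; beyond the scatter), so the two 2-halophenyl rings do not behave alike at this place. Nothing available explains this gap.

Still open, on these data alone, is whether a methyl group, a methoxy group or plain hydrogen at this place would track fluoro or chloro.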